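Imide series: nitrogen substituent swap from benzyl to phenyl

A few compounds are considered here, and "the series" means these few. Any claim that something is new, unique, unknown or untested is made for them only; others in the source may bear on it.

Measured compounds:
compound 1 `O=C1CCCCC1C1CC(=O)N(c2ccccc2)C1=O`: 78300 nM
compound 2 `CC1CCC(=O)C(C2CC(=O)N(Cc3ccccc3)C2=O)C1`: 56200 nM

Both measured compounds were tested in an assay on cells (1-87 tumor cell line) for inhibition of Polyunsaturated fatty acid 5-lipoxygenase (Homo sapiens), with a stated time of 5 min; on this read-out lower numbers stand for stronger inhibition and higher numbers for weaker inhibition. In this assay compound 1 gives 78300 nM and compound 2 gives 56200 nM. Compound 2 thus holds the lower of the two numbers, but its gap to compound 1 is within the scatter, so the two results cannot be told apart.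

The next compound is compound 3 `CC1CCC(=O)C(C2CC(=O)N(c3ccccc3)C2=O)C1`. It differs from compound 2 in one place: phenyl in place of benzyl on an amide-type nitrogen in a ring. Compound 1 also carries the phenyl group on the amide-type nitrogen in the ring, and its number is close to that of compound 2, which is the only pointer available for this change. For the measured compounds named here, no step between measured compounds is known, so the expectation rests on that closeness.

The step from compound 2 to compound 3 is expected to be a 1.2-fold higher number from compound 2 to compound 3 (0.10 log units; within the scatter), that is, no change beyond the scatter in either direction. Compound 3 is accordingly estimated at 70000 nM in this assay, with a range from 30000 nM to 160000 nM.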

Compound 3, half-maximal inhibitory concentration: 69200 nM
Compound 3: the middle estimate sits 1.0-fold (0.00 log units) above what was measured; low and high end bracket the measured number.
By their numbers in this assay, from the lowest: compounds 2, 3 and 1 (each within the scatter of the next).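

In this assay the nitrogen substituent can now be read on its own: phenyl in place of benzyl on the amide-type nitrogen in a ring gives a 1.2-fold higher number from compound 2 to compound 3 (0.09 log units; within the scatter) and so leaves the read-out unchanged within the scatter. Compound 3 also isolates a second place, where methyl in place of hydrogen on a saturated ring carbon gives a 1.1-fold lower number from compound 1 to compound 3 (0.05 log units; within the scatter) and likewise produces no change beyond the scatter, so the closeness of compound 1 and compound 2 no longer rests on a comparison of two simultaneous differences. No accompanying measurement bears on the reason for these small steps.

The compounds shown leave open whether this nitrogen tolerates groups of a different kind, such as a longer phenylethyl chain, a carboxylic acid or an amine carried on the substituent, since phenyl and benzyl are the only two read here. Going by these compounds, it also remains open whether a substituent larger than methyl on the saturated ring carbon, such as tert-butyl, would move the number beyond the scatter in this assay or leave it in place.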